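The source may hold more compounds than are shown below. What is called first, only, known or untested is meant among the compounds shown, and "the series" means these compounds.

Measured compounds:

Compound 1, `CC(C)=CCOc1cc(Nc2nccc(N)n2)ccc1Cl`: 500 nM
Compound 2, `CNc1ccnc(Nc2ccc(Cl)c(OCC=C(C)C)c2)n1`: 690 nM
Compound 3, `CC(C)=CCOc1cc(Nc2nccc(N)n2)ccc1C#N`: 41 nM

Three compounds were tested in an ADME assay on MT2 cells (Homo sapiens) for cytotoxicity; on this read-out higher numbers stand for lower toxicity in this test and lower numbers for higher toxicity in this test. Compound 1 `CC(C)=CCOc1cc(Nc2nccc(N)n2)ccc1Cl` gives 500 nM in this assay, and compound 2 `CNc1ccnc(Nc2ccc(Cl)c(OCC=C(C)C)c2)n1` gives 690 nM. Compound 3 `CC(C)=CCOc1cc(Nc2nccc(N)n2)ccc1C#N` gives 41 nM in this assay, the lowest of the three numbers.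

Compound 2 differs from compound 1 by methyl in place of hydrogen on a nitrogen on an aromatic ring, and that change gave a 1.4-fold higher number from compound 1 to compound 2 (0.14 log units; within the scatter). Compound 3 differs from compound 1 by cyano in place of chloro on an aromatic carbon, a change that gave a 12-fold lower number from compound 1 to compound 3 (1.09 log units; beyond the scatter) in this assay.

Compound 4 `CNc1ccnc(Nc2ccc(C#N)c(OCC=C(C)C)c2)n1` has not yet been measured. It differs from compound 3 by methyl in place of hydrogen on a nitrogen on an aromatic ring, the same change that separates compound 2 from compound 1, made on the core of compound 3 instead of the core of compound 1. Because the earlier methyl step between compound 1 and compound 2 gave a 1.4-fold higher number from compound 1 to compound 2 (0.14 log units; within the scatter), a similarly small step is expected here as well, namely a 1.4-fold higher number from compound 3 to compound 4 (0.14 log units; within the scatter) from compound 3 to compound 4. On that basis compound 4 is estimated to give 57 nM in this assay, with a likely range from 25 nM to 130 nM. Whether the expectation holds was then settled by the measurement of compound 4.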

Compound 4, half-maximal cytotoxic concentration: 22 nM
Compound 4: the middle estimate sits 2.6-fold (0.41 log units) above what was measured; the whole stated range lies above it.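

In this assay, methyl in place of hydrogen on the nitrogen, amino to methylamino, gave a 1.9-fold lower number from compound 3 to compound 4 (0.27 log units; within the scatter), so on neither core did this change move the read-out beyond the scatter, and the two steps do not differ: the same change on two cores in this assay, a 1.4-fold higher number (0.14 log units; within the scatter) from compound 1 to compound 2 and a 1.9-fold lower number (0.27 log units; within the scatter) from compound 3 to compound 4, 2.6-fold (0.41 log units) apart, within the scatter of two such steps. Cyano in place of chloro on an aromatic carbon carried over to the methylamino compounds as well, giving a 31-fold lower number from compound 2 to compound 4 (1.50 log units; beyond the scatter), a large step that does not differ from the earlier one: the same change on two cores in this assay, a 12-fold lower number (1.09 log units; beyond the scatter) from compound 1 to compound 3 and a 31-fold lower number (1.50 log units; beyond the scatter) from compound 2 to compound 4, 2.6-fold (0.41 log units) apart, within the scatter of two such steps. Together these comparisons show that, within the scatter, each change behaved alike on both cores, but they rest on only four compounds in a single assay and do not show that either change would carry over to any other core.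

The compounds shown leave open whether an ethyl group or a longer chain on that nitrogen, or a dimethylamino group in place of methylamino, would also leave the read-out within the scatter. They also leave open how other groups in place of chloro and cyano on that aromatic carbon, such as fluoro or a carboxylic acid, would compare with these two.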